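Enantiomer of compound 3: notes on alpha-galactosidase inhibition

The source may hold more compounds than are shown below. What is called first, only, known or untested is meant among the compounds shown, and "the series" means these compounds.

Measured in an assay on isolated protein for inhibition of alpha-galactosidase (Coffea arabica), tested at 1000 uM; on this read-out higher numbers stand for more inhibition at the one concentration tested (going by the name of the read-out) and lower numbers for less inhibition:
compound 1 `Cc1ccc([C@]2(CO)NC[C@@H](O)[C@@H]2O)cc1`: 1.6%
compound 2 `COc1ccc([C@]2(CO)NC[C@@H](O)[C@@H]2O)cc1`: 7.5%
compound 3 `OC[C@]1(c2ccc(O)cc2)NC[C@H](O)[C@H]1O`: 3.6%

Compound 3 stands second of the three numbers in this assay, nearest to compound 1 and furthest from compound 2, and both gaps lie within the scatter. For the measured compounds named here, the single step in the set, a number 5.9 percentage points higher from compound 1 to compound 2 (within the scatter), is also within the scatter, so nothing among the measured compounds moves the read-out beyond noise.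

Compound 4 `OC[C@@]1(c2ccc(O)cc2)NC[C@@H](O)[C@@H]1O` is not yet measured. It differs from compound 3 as follows: the two compounds have the same atoms and bonds and differ only in configuration as drawn: 3 of 3 stereo elements differ (all stereocentres are inverted: mirror images); a stereocentre at a saturated ring carbon is drawn S in compound 3 and R in compound 4; a stereocentre at a saturated ring carbon is drawn S in compound 3 and R in compound 4; a stereocentre at a saturated ring carbon is drawn S in compound 3 and R in compound 4. Going by the values given here, no measured step concerns a change in configuration, so no step in the set bears directly on this one; the only available step, from compound 1 to compound 2, is within the scatter and gives no direction. All three measured numbers are low and close together, and the expectation is that compound 4 stays in the same low region, with a number 1.4 percentage points higher from compound 3 to compound 4 (within the scatter) expected to be a step not beyond the scatter.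

Estimate for compound 4 in this assay: 5%, in the range 0% to 20%.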

Compound 4, a percentage reported as inhibition, at one concentration (the size of the read-out at that concentration, not a potency): 1.2%
The estimate for compound 4 lay 3.8 percentage points above the measured number; the range from low to high includes it.
By their numbers in this assay, from the lowest: compounds 4, 1, 3 and 2 (each within the scatter of the next).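

Configuration is now tested directly, and in this assay inversion of all stereocentres gives a number 2.4 percentage points lower from compound 3 to compound 4 (within the scatter), so this read-out does not separate the mirror-image pair, a comparison that isolates configuration alone: the fact that compounds 3 and 4 differ only in the configuration as drawn

The aromatic substituent also gains a third member in compound 4: hydrogen in place of methyl on the oxygen gives a number 6.3 percentage points lower from compound 2 to compound 4 (within the scatter), and hydroxy in place of methyl on the aromatic carbon gives a number 0.4 percentage points lower from compound 1 to compound 4 (within the scatter). Neither kind of change therefore moves the number in this assay beyond the scatter among these compounds.

As far as these compounds go, whether an amine or a carboxylic acid on the aromatic ring, or a longer chain on the shared core, would shift the number beyond the scatter remains open. Also open, from the compounds shown here alone, is whether configuration would matter in a compound with a number clearly beyond the scatter from these.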